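Swapping the Para Substituent of a Quinoline Urea Series

This account rests on a few compounds, and the source may have more. Where it says the series, first, only, none or still open, it means among the compounds named here.

Compound 1 `Cc1cc(NC(=O)Nc2ccc(F)cc2)c2ccccc2n1` in an ADME assay on BJ cells (Homo sapiens) for cytotoxicity, with a stated time of 72 h (on this read-out lower numbers stand for an effect already at smaller amounts and higher numbers for an effect only at larger amounts of compound), gives > 25000 nM, a limit of the assay rather than a number.
Compound 2 `Cc1cc(NC(=O)Nc2ccc(O)cc2)c2ccccc2n1` in this assay gives > 25000 nM, also a limit.
Compound 3 `Cc1cc(NC(=O)Nc2ccc(N(C)C)cc2)c2ccccc2n1` in this assay gives > 25000 nM, again a limit.

Within the data shown here, compound 3 therefore stands where every value so far stands, at the limit of > 25000 nM in this assay, at which 3 of the 3 values shown sit. Compound 4 `Cc1cc(NC(=O)Nc2ccc(Cl)cc2)c2ccccc2n1` differs from it by chloro in place of dimethylamino on an aromatic carbon. Among the measured compounds shown here, the steps that bear on such an exchange on the same aromatic carbon are a step that the two limits leave unreadable from compound 1 to compound 2, a step that the two limits leave unreadable from compound 1 to compound 3 and a step that the two limits leave unreadable from compound 2 to compound 3; none of them is readable, so no step beyond the scatter can be inferred in this assay in either direction. Compound 4 is accordingly expected to remain at the limit, with an estimate of 30000 nM between 15000 nM and 100000 nM. The expected step is a step that the limit leaves unreadable from compound 3 to compound 4.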

Compound 4, half-maximal effective concentration: > 25000 nM
Compound 4 was reported as a limit; the forecaster's own chance of this, stated with the estimate: 85%; the middle value lies beyond the limit too.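

No step can be read from compound 4 to compound 1, compound 2 or compound 3, since all four compounds sit at one limit: the limit of > 25000 nM in this assay, at which 4 of the 4 values shown sit.

From the compounds shown here alone, how far each compound lies beyond that limit stays open, and so does whether these exchanges on the aromatic carbon change the read-out at all.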